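The source may hold more compounds than are shown below. What is called first, only, known or untested is meant among the compounds shown, and "the series" means these compounds.

In an ADME assay on microsomes from liver (Mus musculus) for metabolic stability, read by LC-MS, with a stated time of 10 min, tested at 0.5 uM (a lower number here means that less of the compound is left, a higher number that more of the compound is left), compound 1 (`c1ccc2c(c1)CN[C@@H](CN(CC1CCNCC1)[C@H]1CCCc3cccnc31)C2`) gives 13%, compound 2 (`c1ccc2c(c1)CN[C@@H](CN(CCCN1CCNCC1)[C@H]1CCCc3cccnc31)C2`) gives 92% and compound 3 (`c1cnc2c(c1)CCC[C@@H]2N(CCCN1CCNCC1)Cc1cc2ccccc2cn1`) gives 74%. Compound 3 therefore stands second of the three, under compound 2 and far over compound 1.

Compound 4 (`c1cnc2c(c1)CN[C@@H](CN(CCCN1CCNCC1)[C@H]1CCCc3cccnc31)C2`) follows from compound 3 through this change: a group of 10 heavy atoms (8 carbon, 2 nitrogen; one six-membered non-aromatic ring with 1 hetero atom, one six-membered aromatic ring with 1 hetero atom) in place of a group of 10 heavy atoms (9 carbon, 1 nitrogen; one six-membered aromatic ring of carbon only, one six-membered aromatic ring with 1 hetero atom), on a saturated chain carbon bound to an amine nitrogen. The entering group also brings 1 defined stereocentre.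

Among the compounds with values here, the closest precedent is a number 18 percentage points lower from compound 2 to compound 3 (beyond the scatter), a modest step that came with isoquinolin-3-yl in place of 1,2,3,4-tetrahydroisoquinolin-3-yl. Here isoquinolin-3-yl leaves instead, and the entering group, like the group it replaced in that step, has a six-membered non-aromatic ring with 1 hetero atom. The larger a number 79 percentage points higher from compound 1 to compound 2 (beyond the scatter) concerns a part that compound 3 and compound 4 share, so it gives no direct guide. Within the data shown here, no measured compound carries the entering group itself, so only a partial reversal of the step to compound 3 is assumed.

A modest rise in this assay is expected, stated as the estimated a number 12 percentage points higher from compound 3 to compound 4 (beyond the scatter). The estimate for compound 4 is 86%, with an expected range from 68% to 98%.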

Compound 4, percent of the compound remaining: 78%
Beside the measured number, compound 4's estimate is 8 percentage points above it, within the range that was stated.
By their numbers in this assay, from the lowest: compound 1; then compounds 3 and 4 (each within the scatter of the next); then compound 2.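

In this assay the exchange on a saturated chain carbon bound to an amine nitrogen gives a number 4 percentage points higher from compound 3 to compound 4 (within the scatter), so at this place the entering group, with its six-membered non-aromatic ring with 1 hetero atom, cannot be told apart from isoquinolin-3-yl, and the non-aromatic ring alone does not reverse the earlier step away from compound 2. The second comparison gives a number 14 percentage points lower from compound 2 to compound 4 (beyond the scatter), which shows that with a six-membered non-aromatic ring with 1 hetero atom present in both groups, the change from a six-membered aromatic ring of carbon only to a six-membered aromatic ring with 1 hetero atom still registers at this position, with a modest size close to that of the step from compound 2 to compound 3. Nothing at hand accounts for either step.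

Open, going by these compounds, is whether an open-chain aminomethyl group at this place would keep the number near that of compound 4 or of compound 2. Also open, on these data alone, is whether the defined stereocentre matters, and whether a morpholine in place of the piperazine in the 2-(piperazin-1-yl)ethyl part would hold up alongside either group.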